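Two methoxy groups on a shared indole core

The source may report more compounds than this note shows. Statements on the series, on what has been measured and on what is new or still open speak of the compounds shown alone.

Compound 1 `CC(=O)c1cc(-c2ccc(F)cc2)cc2cc(-c3ccccc3)[nH]c12` gives 82.7% in a functional assay on MCF7 cells (Homo sapiens) for cytotoxicity, read by MTT assay, with a stated time of 2 days, tested at 1 uM; a higher number here means a weaker effect of the compound at the concentration tested, a lower number a stronger effect. Compound 2 `COc1ccc(-c2cc(C(C)=O)c3[nH]c(-c4ccccc4)cc3c2)cc1` differs from it by methoxy in place of fluoro on an aromatic carbon, and in this assay compound 2 gives 88.8%, a step of a number 6.1 percentage points higher from compound 1 to compound 2 (within the scatter). Compound 3 `COc1ccc(-c2cc3cc(-c4ccc(F)cc4)cc(C(C)=O)c3[nH]2)cc1` differs from compound 1 by methoxy in place of hydrogen on an aromatic carbon; in this assay compound 3 gives 96.4%, a step of a number 13.7 percentage points higher from compound 1 to compound 3 (beyond the scatter).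

Compound 4 `COc1ccc(-c2cc(C(C)=O)c3[nH]c(-c4ccc(OC)cc4)cc3c2)cc1` has not yet been measured. It differs from compound 3 by methoxy in place of fluoro on an aromatic carbon, the same change that separates compound 1 from compound 2, at a place described in the same words. Within the data shown here, the one measured example of this change, the step of a number 6.1 percentage points higher from compound 1 to compound 2 (within the scatter), stayed within the scatter, so the expected step from compound 3 to compound 4 is small as well, estimated at a number 2.6 percentage points higher from compound 3 to compound 4 (within the scatter). On that basis compound 4 is expected to give about 99% in this assay, with a likely range from 88% to 108%.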

Compound 4, a percentage reported as activity, at one concentration (the size of the read-out at that concentration, not a potency): 62.6%
The estimate for compound 4 lay 36.4 percentage points above the measured number; measured number outside the range, below it.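

In this assay, exchanging fluoro for methoxy, 4-fluorophenyl to 4-methoxyphenyl, gave a step of a number 33.8 percentage points lower from compound 3 to compound 4 (beyond the scatter), so this change did not carry over unchanged from one core to the other: the same change on two cores in this assay, a number 6.1 percentage points higher (within the scatter) from compound 1 to compound 2 and a number 33.8 percentage points lower (beyond the scatter) from compound 3 to compound 4, 39.9 percentage points apart, beyond the scatter of two such steps

The companion change, methoxy in place of hydrogen, behaved the same way, with a step of a number 26.2 percentage points lower from compound 2 to compound 4 (beyond the scatter), reversing the direction it had taken on the other core: the same change on two cores in this assay, a number 13.7 percentage points higher (beyond the scatter) from compound 1 to compound 3 and a number 26.2 percentage points lower (beyond the scatter) from compound 2 to compound 4, 39.9 percentage points apart, beyond the scatter of two such steps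

The two methoxy groups therefore do not add up independently in this series, but these four compounds, read at a single concentration in one cell line, give no cause for this and no rule for other changes on these cores.

The compounds shown leave open whether the lower number requires methoxy on both rings, or whether an ethoxy group or a dimethylamino group at the same places would also give it. They also leave open whether a hydroxy group in place of either methoxy would preserve the step.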